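Amide variation across a shared core: cytotoxicity notes

The source may report more compounds than this note shows. Statements on the series, on what has been measured and on what is new or still open speak of the compounds shown alone.

Measured compounds:
Compound 1 `CCCC(=O)Nc1ncc(-c2ccc(OC)cc2)n1C` — in a toxicity assay on THP-1 cells (Homo sapiens) for inhibition (on this read-out higher numbers stand for lower toxicity in this test and lower numbers for higher toxicity in this test), compound 1 gives > 100000 nM, which is a limit of the assay.
Compound 2 `COc1ccc(-c2cnc(NC(=O)c3ccccc3)n2C)cc1` — in this assay compound 2 gives > 100000 nM, again a limit.
Compound 3 `COc1ccc(-c2cnc(NC(=O)c3cccc(OC)c3)n2C)cc1` — in this assay compound 3 gives > 100000 nM, also a limit.

Compound 3 thus stands at the same limit as the two other compounds, with no number of its own to place it. The unmeasured compound 4 `COc1ccc(C(=O)Nc2ncc(-c3ccc(OC)cc3)n2C)cc1` differs from compound 3 in one place: 4-methoxyphenyl in place of 3-methoxyphenyl on a carbonyl carbon.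

Bearing on this step are a step that the two limits leave unreadable from compound 2 to compound 3 and a step that the two limits leave unreadable from compound 1 to compound 3, both unreadable in size, as is a step that the two limits leave unreadable from compound 1 to compound 2. Nothing here separates any amide variant from another in this assay, due to the limit of > 100000 nM in this assay, at which 3 of the 3 values shown sit. No shift beyond the scatter is expected for compound 4, and the outcome is most likely another limit.

Compound 4 is estimated at 100000 nM, with a range from 50000 nM to 200000 nM. The step expected in this assay is a number no higher from compound 3 to compound 4 (the limit leaves the size open).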

Compound 4, half-maximal cytotoxic concentration: > 100000 nM
Compound 4: no number, only a limit; the forecaster's own chance of this, stated with the estimate: 85%; the middle value sits exactly at the limit.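

No step can be read from compound 1, compound 2 or compound 3 to compound 4, because all four compounds stand at the same limit: the limit of > 100000 nM in this assay, at which 4 of the 4 values shown sit.

Left open is whether any of these amide variants differs from another in this assay, and at what concentration any of them would become toxic.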